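Working notes: the step from compound 3 to compound 4

This account rests on a few compounds, and the source may have more. Where it says the series, first, only, none or still open, it means among the compounds named here.

In a functional assay on RT-112 cells (Homo sapiens) for antiproliferative activity, read by MTT assay, with a stated time of 72 h (a higher number here means a weaker inhibitor of growth, a lower number a stronger inhibitor of growth), compound 1 `COc1cc(Nc2ncnc3c(NC(=O)Nc4ccccc4Cl)cccc23)cc(OC)c1` gives 356 nM, and compound 3 `COc1cc(Nc2ncnc3c(NC(=O)Nc4ccc(F)cc4F)cccc23)cc(OC)c1` gives 2460 nM, the higher of the two exact numbers. The step between them is a 6.9-fold higher number from compound 1 to compound 3 (0.84 log units; beyond the scatter). Compound 2 `COc1cc(Nc2ncnc3c(NC(=O)Nc4ccc(Cl)c(C(F)(F)F)c4)cccc23)cc(OC)c1` gives > 20000 nM, which is a limit of the assay.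

Compound 4 `COc1cc(Nc2ncnc3c(NC(=O)Nc4cccc(C(F)(F)F)c4F)cccc23)cc(OC)c1` differs from compound 3 by 2-fluoro-3-(trifluoromethyl)phenyl in place of 2,4-difluorophenyl on an amide-type nitrogen. Among the measured compounds shown here, the only measured group carrying trifluoromethyl is that of compound 2, so two steps bear most: the large at least 56-fold higher number from compound 1 to compound 2 (1.74 log units; beyond the scatter) and the at least modest an at least 8.1-fold lower number from compound 2 to compound 3 (0.91 log units; beyond the scatter). A modest step to a higher number is therefore expected in this assay, estimated as a 2.2-fold higher number from compound 3 to compound 4 (0.35 log units; beyond the scatter). For compound 4 the estimate is 5500 nM, with an expected range of 1500 nM to 20000 nM.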

Compound 4, concentration for 50% growth inhibition: 471 nM
Compound 4: middle estimate off by 12-fold (1.07 log units), on the high side, outside the stated range (below it).
By their numbers in this assay, from the lowest: compounds 1 and 4 (each within the scatter of the next); then compound 3. At a limit, above all of these: compound 2.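

Trifluoromethyl on this aryl group is compatible with activity in this assay: 2-fluoro-3-(trifluoromethyl)phenyl on the amide-type nitrogen gives a 5.2-fold lower number from compound 3 to compound 4 (0.72 log units; beyond the scatter), so the weak reading of compound 2 does not extend to every trifluoromethyl group. The new group also reads level with 2-chlorophenyl, at a 1.3-fold higher number from compound 1 to compound 4 (0.12 log units; within the scatter). The remaining step, an at least 42-fold lower number from compound 2 to compound 4 (1.62 log units; beyond the scatter), starts from a limit and is only a bound: the limit of > 20000 nM in this assay, at which 1 of the 4 values shown sits.

The compounds shown do not separate the contribution of the trifluoromethyl from that of the fluorine in this group. From the compounds shown here alone, how a methoxy, an amine or a carboxylic acid on this phenyl ring would read also stays open.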